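A few compounds are considered here, and "the series" means these few. Any claim that something is new, unique, unknown or untested is made for them only; others in the source may bear on it.

Three compounds have so far been measured in a physicochemical assay for metabolic stability, read by HPLC, in phosphate buffer, at pH 7.7; a lower number here means that the compound disappears faster, a higher number that the compound lasts longer:

compound 1, `CC(=O)N[C@@H](C)C(=O)N(C)/N=N/c1ccc(Br)cc1`, 25.5 h
compound 2, `CC(=O)N[C@@H](C)C(=O)N(C)/N=N/c1ccc(C(N)=O)cc1`, 18.4 h
compound 3, `CC(=O)NCC(=O)N(C)/N=N/c1ccc(C#N)cc1`, 7.6 h

Compound 2 stands second highest of these three. Its nearest neighbour is compound 1, and the step of a 1.4-fold lower number from compound 1 to compound 2 (0.14 log units; within the scatter) lies within the scatter. Among the compounds with values here, compound 3 gives the lowest number, but it also differs from compound 2 in the core, so no single-point step connects them.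

Compound 4, `CC(=O)N[C@@H](C)C(=O)N(C)/N=N/c1ccc(C(C)=O)cc1`, differs from compound 2 by methyl in place of amino on a carbonyl carbon, which read one bond further out is carbamoyl to acetyl. Within the data shown here, the only measured step at this aromatic carbon, a 1.4-fold lower number from compound 1 to compound 2 (0.14 log units; within the scatter), was within the scatter, and nothing in the set speaks for a larger change here. The step of a 1.0-fold lower number from compound 2 to compound 4 (0.01 log units; within the scatter) is therefore expected to stay within the scatter. Compound 4 is estimated at 18 h, with a range from 9 h to 36 h.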

Compound 4, half-life: 13.9 h
The estimate for compound 4 lay 1.3-fold (0.11 log units) above the measured number, within the range that was stated.
By their numbers in this assay, from the lowest: compounds 3, 4, 2 and 1 (each within the scatter of the next, the first and the last beyond it).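

In this assay, methyl in place of amino on the carbonyl carbon gives a 1.3-fold lower number from compound 2 to compound 4 (0.12 log units; within the scatter) and stays within the scatter, so this change of the carbamoyl to acetyl now has a measured step of its own. Acetyl in place of bromo on the aromatic carbon gives a 1.8-fold lower number from compound 1 to compound 4 (0.26 log units; within the scatter) and also stays within the scatter, so bromo, carbamoyl and acetyl cannot be told apart at this aromatic carbon on the shared core. Nothing available accounts for these steps. From the compounds shown here alone, whether an amine or a carboxylic acid at this aromatic carbon would also stay within the scatter remains open. So does the separate contribution of the core of compound 3 and its nitrile.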